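Side-chain size at the amino-acid carbon: sec-butyl to methyl

The source may report more compounds than this note shows. Statements on the series, on what has been measured and on what is new or still open speak of the compounds shown alone.

Measured so far in a functional assay on the whole organism (Tail, strain ICR) with Mus musculus as the target, in the tail flick test, with a stated time of 150 min, at a dose of 25 umol/kg by the oral route; on this read-out higher numbers stand for a stronger effect at the one dose given and lower numbers for a weaker effect:
- compound 1 `CC(C)[C@H](NC(=O)CN(c1ncnc2c1ncn2C1CCCCO1)C1CC1)C(=O)OCc1ccccc1`: 21.1%
- compound 2 `CC[C@H](C)[C@H](NC(=O)CN(c1ncnc2c1ncn2C1CCCCO1)C1CC1)C(=O)OCc1ccccc1`: 16.4%

Compound 2 has the lower of the two numbers in this assay, yet its separation from compound 1 is a number 4.7 percentage points lower from compound 1 to compound 2 (within the scatter), so the two cannot be ordered.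

Compound 3 `C[C@H](NC(=O)CN(c1ncnc2c1ncn2C1CCCCO1)C1CC1)C(=O)OCc1ccccc1` is the unmeasured member. It differs from compound 2 by methyl in place of sec-butyl on a saturated chain carbon bound to an amide-type nitrogen and a carbonyl carbon — the side chain at that carbon is cut back to a single carbon.

Within the data shown here, the only step that bears on this position is the one from compound 1 to compound 2, which added a methyl there and gave a number 4.7 percentage points lower from compound 1 to compound 2 (within the scatter). Nothing beyond the scatter has been seen at this carbon, so the expected step of a number 2.6 percentage points higher from compound 2 to compound 3 (within the scatter) from compound 2 to compound 3 in this assay is none beyond the scatter. Compound 3 is therefore estimated at 19%, with a range from 8% to 31%.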

Compound 3, a percentage reported as activity, at one dose (the size of the read-out at that dose, not a potency): 6.01%
Beside the measured number, compound 3's estimate is 13 percentage points above it, and the stated range ends above it.
By their numbers in this assay, from the lowest: compound 3; then compounds 2 and 1 (each within the scatter of the next).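

In this assay, the side chain at this carbon now registers: methyl in place of sec-butyl gives a number 10.4 percentage points lower from compound 2 to compound 3 (beyond the scatter) and methyl in place of isopropyl gives a number 15.1 percentage points lower from compound 1 to compound 3 (beyond the scatter), whereas the earlier exchange of isopropyl for sec-butyl gave no step beyond the scatter. Compounds 1 and 2 still cannot be ordered, but each stands clearly above compound 3, so among these three compounds the methyl side chain gives the lowest number. Nothing available bears on what lies behind this result.

The compounds shown leave open whether an ethyl side chain would read with methyl or with the two larger groups. They also leave open whether a benzyl group or a longer chain at this carbon would hold the number, raise it or lower it.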